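Methyl in Place of Chloro: What to Expect Next

The source may report more compounds than this note shows. Statements on the series, on what has been measured and on what is new or still open speak of the compounds shown alone.

Measured in an assay on isolated protein for inhibition of Aromatase (Homo sapiens), read by fluorescence and colorimetric assay, with a stated time of 30 min; a higher number here means a weaker inhibitor, a lower number a stronger inhibitor:
- compound 1 `c1ccc(Cn2cc(COc3ccccc3)nn2)cc1`: 10600 nM
- compound 2 `Clc1ccc(OCc2cn(Cc3ccccc3)nn2)cc1`: 5040 nM

Compound 2 has the lower of these two numbers, which in this assay means the stronger inhibitor of the pair. Among the compounds with values here, its only neighbour is compound 1, and the step of a 2.1-fold lower number from compound 1 to compound 2 (0.32 log units; beyond the scatter) sets it apart beyond the usual scatter.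

Compound 3 `Cc1ccc(OCc2cn(Cc3ccccc3)nn2)cc1` differs from compound 2 in one place: methyl in place of chloro on an aromatic carbon. Within the data shown here, no measured pair compares methyl directly with chloro here. Among the measured compounds shown here, the only step that bears on this position is a 2.1-fold lower number from compound 1 to compound 2 (0.32 log units; beyond the scatter), which shows that putting a group onto this carbon, instead of hydrogen, gave a modest gain. Whether methyl holds that gain as chloro did is not settled by the two numbers available, so only a small step, if any beyond the scatter, is expected from compound 2 to compound 3, namely a 1.3-fold higher number from compound 2 to compound 3 (0.11 log units; within the scatter).

On that basis compound 3 is estimated at 6500 nM, with a range from 3000 nM to 14000 nM.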

Compound 3, half-maximal inhibitory concentration: 2270 nM
Compound 3: the middle estimate sits 2.9-fold (0.46 log units) above what was measured; the measured number lies below the stated range.
By their numbers in this assay, from the lowest: compound 3; then compound 2; then compound 1.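

Chloro was not the limit at this carbon: swapping it for methyl gives a 2.2-fold lower number from compound 2 to compound 3 (0.35 log units; beyond the scatter) and shows that two groups of one heavy atom each, placed on the same aromatic carbon, can be told apart in this assay. Measured against plain hydrogen, methyl gives a 4.7-fold lower number from compound 1 to compound 3 (0.67 log units; beyond the scatter) and so makes the largest step among these three compounds, which puts them in the order hydrogen, chloro, methyl, with each compound a stronger inhibitor than the one before. No measurement at hand accounts for methyl outdoing chloro, so the result stands as an observation without an explanation.

The compounds shown leave open whether the gain continues with a longer chain such as ethyl, or changes with a group of another kind, such as methoxy or an amine, at this same carbon. They also leave open whether methyl would give a similar gain on another carbon of this ring, since every substituent compared here sits para to the large group.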